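A few compounds are considered here, and "the series" means these few. Any claim that something is new, unique, unknown or untested is made for them only; others in the source may bear on it.

Compound 1 `CN(C)c1ccc(CN(Cc2cccc(-c3cc[nH]n3)c2)C(=O)Nc2c(F)cc(F)cc2F)cc1`: < 0.32 mg/kg
Compound 2 `COc1ccc(CN(Cc2cccc(-c3cc[nH]n3)c2)C(=O)Nc2c(SC)cc(C)nc2SC)cc1`: < 0.1 mg/kg
Compound 3 `COc1cccc(CN(Cc2cccc(-c3cc[nH]n3)c2)C(=O)Nc2c(SC)cc(C)nc2SC)c1`: > 0.1 mg/kg
Compound 4 `CSc1cc(C)nc(SC)c1NC(=O)N(Cc1ccc(N(C)C)cc1)Cc1cccc(-c2cc[nH]n2)c1`: not yet measured

All three measured compounds were tested in a functional assay on a cell-free system (plasma) with sterol O-acyltransferase, Soat (Rattus norvegicus) as the target; a higher number here means that more compound is needed for the effect, a lower number that less compound is needed. For compound 3 the value > 0.1 mg/kg is a limit of the assay, not a number (the limit of > 0.1 mg/kg in this assay, at which 1 of the 3 values shown sits). For compound 2 the value < 0.1 mg/kg is likewise a limit (the limit of < 0.1 mg/kg in this assay, at which 1 of the 3 values shown sits), so the step of a number no lower from compound 2 to compound 3 (the limit leaves the size open) is known only in direction, not in size. Compound 4 differs from compound 3 in one place: 4-(dimethylamino)phenyl in place of 3-methoxyphenyl on a saturated chain carbon bound to an amide-type nitrogen. Among the measured compounds shown here, no measured step covers exactly this change. Compound 1 carries the same 4-(dimethylamino)phenyl but otherwise differs from compound 4 as well; in this assay compound 1 gives < 0.32 mg/kg, again a limit (the limit of < 0.32 mg/kg in this assay, at which 1 of the 3 values shown sits). What the three values share is that a 4-substituted ring, as in compound 2, sits at or beyond the lower limit, while the 3-methoxyphenyl of compound 3 sits at or beyond the upper one. Compound 4 is therefore expected to come in at 0.1 mg/kg, within a range of 0.03 mg/kg to 0.4 mg/kg. That would mean an expected step of a number no higher from compound 3 to compound 4 (the limit leaves the size open), most likely reported once more as a limit.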

Compound 4, dose for half-maximal effect: < 0.1 mg/kg
Compound 4 ended at the assay's limit; the forecaster's own chance of this, stated with the estimate: 55%; the middle value lies on the limit itself.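

In this assay, putting 4-(dimethylamino)phenyl in place of 3-methoxyphenyl on a saturated chain carbon bound to an amide-type nitrogen gives a number no higher from compound 3 to compound 4 (the limit leaves the size open). Compound 4 gives < 0.1 mg/kg, which is a limit of the assay and not a number: the limit of < 0.1 mg/kg in this assay, at which 2 of the 4 values shown sit. Compound 2 sits at this same limit, so a second group on a 4-substituted phenyl ring, dimethylamino rather than methoxy, also reaches it on the shared core.

The steps to compound 4 from compound 2 and from compound 1 cannot be read, so these compounds cannot be ranked against it. The step from compound 3 changes both the group and its place on the ring, and the compounds shown do not separate those two changes: that would take 3-(dimethylamino)phenyl, while a morpholine or a carboxylic acid in place of dimethylamino also remains open.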